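A few compounds are considered here, and "the series" means these few. Any claim that something is new, unique, unknown or untested is made for them only; others in the source may bear on it.

Compound 1 `COc1cccc(-c2ccc3ccc(C)nc3c2)c1` gives 860 nM in a functional assay on CHO cells for inhibition of metabotropic glutamate receptor 5 (Rattus norvegicus), read by FLIPR and calcium flux; a lower number here means a stronger inhibitor, a higher number a weaker inhibitor.
Compound 2 `Cc1ccc2ccc(-c3cccc(CO)c3)cc2n1` gives 8700 nM.
Compound 3 `COc1cc(C#N)cc(-c2ccc3ccc(C)nc3c2)c1` gives 2.4 nM.

Going by the values given here, of the three numbers, the one for compound 3 is the lowest, the result of the large step of a 360-fold lower number from compound 1 to compound 3 (2.55 log units; beyond the scatter), while the step of a 10-fold higher number from compound 1 to compound 2 (1.01 log units; beyond the scatter) went the other way. Compound 4 `Cc1ccc2ccc(-c3cc(C#N)cc(OCC(C)C)c3)cc2n1` differs from compound 3 by isopropyl in place of hydrogen on a saturated chain carbon bound to an oxygen on an aromatic ring. Among the compounds with values here, no measured step makes this change: the step of a 10-fold higher number from compound 1 to compound 2 (1.01 log units; beyond the scatter) touches the same methoxy but replaces it rather than lengthening it, and the step of a 360-fold lower number from compound 1 to compound 3 (2.55 log units; beyond the scatter) concerns the cyano, which compound 4 keeps. Without a direct precedent, only a modest step of a 3.3-fold higher number from compound 3 to compound 4 (0.52 log units; beyond the scatter) is expected for compound 4. Compound 4 is therefore estimated at 8 nM, with a range from 2 nM to 40 nM.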

Compound 4, half-maximal inhibitory concentration: 12000 nM
Beside the measured number, compound 4's estimate is 1500-fold (3.18 log units) below it, and the stated range ends below it.
By their numbers in this assay, from the lowest: compound 3; then compound 1; then compounds 2 and 4 (each within the scatter of the next).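

The step of a 5000-fold higher number from compound 3 to compound 4 (3.70 log units; beyond the scatter) shows that in this assay this place, on a saturated chain carbon bound to an oxygen on an aromatic ring, accepts methoxy but not isobutoxy, and that the nitrile kept in compound 4 does not offset the change. The earlier compounds shown here replaced the methoxy but never lengthened it, so this sensitivity had not appeared. Nothing available explains the loss.

Still open, on these data alone, is whether an ethoxy already costs this much, or whether only the isobutyl chain does. Equally open, as far as these compounds go, is how an unbranched propoxy or a chain ending in an amine would read.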